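This account rests on a few compounds, and the source may have more. Where it says the series, first, only, none or still open, it means among the compounds named here.

Measured in a physicochemical assay for solubility; on this read-out higher numbers stand for higher solubility and lower numbers for lower solubility:

- compound 1 `CCCC(=O)n1c(=S)[nH]c2ccccc21`: 190000 nM
- compound 2 `CCn1c(=S)n(C(C)=O)c2ccccc21`: 380000 nM

Only these two compounds have numbers in this assay. Compound 1 holds the lower number of the pair at 190000 nM, but the gap to compound 2 at 380000 nM lies within the usual scatter of repeated measurements, so the two values do not separate them. Compound 3 `O=C(CCc1ccccc1)n1c(=S)[nH]c2ccccc21` has not yet been measured. It departs from compound 1 by one change: phenyl in place of methyl on a saturated chain carbon, two bonds along the chain from a carbonyl carbon. In words, this is phenyl in place of methyl on a saturated chain carbon, two bonds along the chain from a carbonyl carbon.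

Going by the values given here, no measured pair in this small set shows this change or anything like it, so the data offer no direct guide to its size. The expectation is therefore a cautious one: a moderate fall in this assay that probably exceeds the scatter, starting from the 190000 nM of compound 1. The estimated change is a 4.8-fold lower number from compound 1 to compound 3 (0.68 log units; beyond the scatter). For compound 3 the expected value is 40000 nM, with an estimated range of 10000 nM to 130000 nM.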

Compound 3, solubility: 100000 nM
For compound 3 the middle estimate is 2.5-fold (0.40 log units) below the measured one; measured number inside the range.
By their numbers in this assay, from the lowest: compounds 3, 1 and 2 (each within the scatter of the next, the first and the last beyond it).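

In this assay, phenyl in place of methyl on a saturated chain carbon, two bonds along the chain from a carbonyl carbon, gives a 1.9-fold lower number from compound 1 to compound 3 (0.28 log units; within the scatter), so this single step does not separate the two compounds. Going by these compounds alone, it is the first reading of any change at this position, and it shows that a group of 6 heavy atoms with one six-membered aromatic ring, entering where a methyl of 1 heavy atom stood, leaves the read-out within the scatter of compound 1. Nothing available on these compounds accounts for this result.

Still open, as far as these compounds go, is how other groups at this place would read in this assay, for instance an amine, a carboxylic acid or a longer chain ending in the same phenyl. Also open, from the compounds shown here alone, is whether phenyl in place of methyl would give a similar step on the core of compound 2, since this change is seen only once, on the core of compound 1.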